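The source may report more compounds than this note shows. Statements on the series, on what has been measured and on what is new or still open speak of the compounds shown alone.

Compound 1 `COc1cc(C(=O)c2sc(-c3cccc([N+](=O)[O-])c3)cc2N)cc(OC)c1OC`: 7.5 nM
Compound 2 `COc1cc(C(=O)c2sc(-c3ccccc3)cc2N)cc(OC)c1OC`: 5.3 nM
Compound 3 `COc1cc(C(=O)c2sc(-c3ccc(F)cc3)cc2N)cc(OC)c1OC`: 12 nM

In a functional assay on MOLT-4 cells (Homo sapiens) for antiproliferative activity (a higher number here means a weaker inhibitor, a lower number a stronger inhibitor), compound 1 stands second highest of the three numbers, with both other compounds within the scatter of it. Compound 4 `COc1cc(C(=O)c2sc(-c3ccc(C)cc3)cc2N)cc(OC)c1OC` differs from compound 1 as follows: 4-methylphenyl in place of 3-nitrophenyl on an aromatic carbon. The nearest measured parallel also puts 4-fluorophenyl in place of 3-nitrophenyl, a 1.6-fold higher number from compound 1 to compound 3 (0.20 log units; within the scatter). Going by the values given here, removing the nitro group gives a 1.4-fold lower number from compound 1 to compound 2 (0.15 log units; within the scatter), and the only step beyond the scatter is modest, a 2.3-fold higher number from compound 2 to compound 3 (0.35 log units; beyond the scatter). With steps this small, no change beyond the scatter is expected in this assay, and no direction can be favoured. The estimate is a 1.1-fold higher number from compound 1 to compound 4 (0.03 log units; within the scatter). Compound 4 is expected at 8 nM, with an estimated range of 3 nM to 22 nM.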

Compound 4, half-maximal inhibitory concentration: 16 nM
The estimate for compound 4 lay 2.0-fold (0.30 log units) below the measured number; the measured number falls inside the stated range.
By their numbers in this assay, from the lowest: compounds 2, 1, 3 and 4 (each within the scatter of the next, the first and the last beyond it).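

At this aromatic carbon next to the ring sulfur, adding methyl to the phenyl of compound 2 raises the number in this assay (a 3.0-fold higher number from compound 2 to compound 4 (0.48 log units; beyond the scatter)), and 4-methylphenyl in place of 3-nitrophenyl also does so (a 2.1-fold higher number from compound 1 to compound 4 (0.33 log units; beyond the scatter)). The 4-methylphenyl and 4-fluorophenyl groups cannot be told apart (a 1.3-fold higher number from compound 3 to compound 4 (0.12 log units; within the scatter)), yet both stand beyond the scatter of the unsubstituted phenyl. Nothing available explains these steps.

The compounds leave open whether a 4-ethylphenyl or an amine on the phenyl would follow the same trend.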